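The source may hold more compounds than are shown below. What is called first, only, known or untested is meant among the compounds shown, and "the series" means these compounds.

Measured so far:
- Compound 1, `Cc1ccc(Nc2nc(Cl)nc3c2ncn3Cc2ccc(C(=O)Nc3ccccc3N)cc2)cc1`: 82%
- Compound 2, `Cc1ccc(Nc2nc(Cl)nc3c2ncn3Cc2ccc(/C=C/C(=O)Nc3ccccc3N)cc2)cc1`: 43%
- Compound 3, `CC(C)n1cnc2c(Nc3cccc(Cl)c3)nc(NCOCc3ccc(C(=O)Nc4ccccc4N)cc3)nc21`: 60.5%

These three compounds were tested in a functional assay on HepG2 cells (Homo sapiens) for antiproliferative activity, read by CCK-8 assay, with a stated time of 72 h, tested at 8 uM; on this read-out lower numbers stand for a weaker effect and higher numbers for a stronger effect at the one concentration tested. Compound 1 and compound 2 share a core and differ in one place only: 2-((2-aminophenyl)carbamoyl)ethenyl in place of (2-aminophenyl)carbamoyl on an aromatic carbon. That single change gave a number 39 percentage points lower from compound 1 to compound 2 (beyond the scatter).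

Compound 3 is built on a different core; the difference between the two cores is not broken down here. In this assay compound 3 gives 60.5%, which lies between the values of compound 1 and compound 2.

Compound 4, `CC(C)n1cnc2c(Nc3cccc(Cl)c3)nc(NCOCc3ccc(/C=C/C(=O)Nc4ccccc4N)cc3)nc21`, has not yet been measured. It stands to compound 3 as compound 2 stands to compound 1: 2-((2-aminophenyl)carbamoyl)ethenyl in place of (2-aminophenyl)carbamoyl on an aromatic carbon. The place described for this change is the same as for the change from compound 1 to compound 2, so it is the same change made on the other core.

Going by the values given here, the expectation for compound 4 rests on the one earlier example of this change, because a number 39 percentage points lower from compound 1 to compound 2 (beyond the scatter) was large. Among the compounds with values here, the change is expected to lower the read-out again, though since only one example exists the size on the new core is uncertain, so the expected step from compound 3 to compound 4 is a number 30.5 percentage points lower from compound 3 to compound 4 (beyond the scatter). Compound 4 is therefore estimated at 30% in this assay, with a range from 10% to 55%.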

Compound 4, a percentage reported as inhibition, at one concentration (the size of the read-out at that concentration, not a potency): 49.9%
The estimate for compound 4 lay 19.9 percentage points below the measured number, and the stated range covers the measured number.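

In this assay, putting 2-((2-aminophenyl)carbamoyl)ethenyl in place of (2-aminophenyl)carbamoyl on the core of compound 3 gave a number 10.6 percentage points lower from compound 3 to compound 4 (beyond the scatter), so the direction of the change carried over from the first core to the second. The size of the step did not carry over, as setting the two steps side by side shows: the same change on two cores in this assay, a number 39 percentage points lower (beyond the scatter) from compound 1 to compound 2 and a number 10.6 percentage points lower (beyond the scatter) from compound 3 to compound 4, 28.4 percentage points apart, beyond the scatter of two such steps. Two cores show only that the read-out fell both times; they do not explain the difference in size or show that the same direction would hold on a further core, and a reading at one concentration is not a potency.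

The two cores differ in more than one place, so the compounds shown leave open which part of a core governs the size of the step. They also leave open how the series would respond to a longer chain in place of the ethenyl link, or to a hydroxamic acid in place of the 2-aminophenyl amide.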